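A Chloro to Nitro Swap on an Aromatic Ring

The source may hold more compounds than are shown below. What is called first, only, known or untested is meant among the compounds shown, and "the series" means these compounds.

Measured compounds:
- Compound 1, `COc1cc(/C=N/NC(=O)CCCc2nc3ccccc3c(=O)[nH]2)cc(O)c1O`: 88000000 nM
- Compound 2, `O=C(CCc1nc2ccccc2c(=O)[nH]1)N/N=C/c1ccc(Cl)cc1`: 381000000 nM

The two compounds were compared in a physicochemical assay, read by spectrophotometry, with a stated time of 30 min; a higher number here means a weaker inhibitor, a lower number a stronger inhibitor. Compound 2 gives 381000000 nM in this assay, the highest of the two numbers. Its nearest neighbour is compound 1, whose value of 88000000 nM lies lower by a gap that is beyond the usual scatter of such measurements. Going by the values given here, no single-point step between measured compounds exists, so the two values show only that compound 2 is the weaker of the pair.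

Compound 3, `O=C(CCc1nc2ccccc2c(=O)[nH]1)N/N=C/c1ccc([N+](=O)[O-])cc1`, has not yet been measured. It differs from compound 2 in one place: nitro in place of chloro on an aromatic carbon.

Among the compounds with values here, with no measured step of this kind to draw on, the expected change from compound 2 to compound 3 in this assay is a 1.1-fold lower number from compound 2 to compound 3 (0.04 log units; within the scatter), that is, no step beyond the scatter in either direction. Compound 3 is accordingly estimated at 350000000 nM, with a plausible range from 120000000 nM to 1000000000 nM.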

Compound 3, half-maximal inhibitory concentration: 328000000 nM
For compound 3 the middle estimate is 1.1-fold (0.03 log units) above the measured one; measured number inside the range.
By their numbers in this assay, from the lowest: compound 1; then compounds 3 and 2 (each within the scatter of the next).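

Going by these compounds alone, the exchange of chloro for nitro on an aromatic carbon, para to a large group, provides the first single-place step in this assay: a 1.2-fold lower number from compound 2 to compound 3 (0.07 log units; within the scatter). The earlier pair, compound 1 and compound 2, differed in more than one place and so could say nothing about this position alone. It is now seen that going from 4-chlorophenyl to 4-nitrophenyl, with one heavy atom leaving, three entering and two hydrogen-bond acceptors added, produces no step beyond the scatter. No supporting measurement bears on why these two groups read alike in this assay.

The compounds shown leave open whether this position accepts other groups equally, since an amine or a carboxylic acid on the same aromatic carbon might give a step beyond the scatter where nitro gives none. They also leave open whether the same exchange would read alike on the longer chain carried by compound 1.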